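The compounds below may be only part of what the source reports. "The series", "measured", "known", "first", "only" and "open" are said of these compounds alone.

Of the compounds shown here, two that share one core have been measured in a physicochemical assay for lipophilicity; a higher number here means a more lipophilic compound, a lower number a more polar compound. Compound 1 `CCCC(C)OC(=O)CNC(=O)C(CSc1ccc([N+](=O)[O-])cc1[N+](=O)[O-])NC(=O)CCC(NC(=O)OCc1ccccc1)C(=O)O` gives 2.8 in this assay. Compound 2 `CCC(C)OC(=O)CNC(=O)C(CSc1ccc([N+](=O)[O-])cc1[N+](=O)[O-])NC(=O)CCC(NC(=O)OCc1ccccc1)C(=O)O` gives 2.72 in this assay. Among the measured compounds shown here, the single measured step between them, a number 0.08 log units lower from compound 1 to compound 2 (within the scatter), swaps hydrogen for methyl on a saturated chain carbon, three bonds along the chain from an oxygen next to a carbonyl group, and changes little. On the numbers shown, compound 2 therefore sits alongside compound 1, the two differing by less than the scatter.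

Compound 3 `CCC(C)OC(=O)CNC(=O)C(CSc1ccc([N+](=O)[O-])cc1[N+](=O)[O-])NC(=O)CCC(NC(=O)OCc1ccccc1)C(=O)OC(C)CC` has not been measured. It differs from compound 2 in one place: sec-butyl in place of hydrogen on an oxygen next to a carbonyl group, so that a carboxy group becomes a sec-butoxycarbonyl group. For the measured compounds named here, the only measured step, from compound 1 to compound 2, concerns a small alkyl exchange on a chain carbon and offers no direct precedent for replacing the hydrogen of a carboxy group, so the expectation rests on the change itself, which adds four carbon atoms and removes a hydrogen-bond donor. The step from compound 2 to compound 3 is expected to be upward and well beyond the scatter, a number 1.78 log units higher from compound 2 to compound 3 (beyond the scatter). Compound 3 is accordingly estimated at 4.5, within a range of 3.6 to 5.4.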

Compound 3, partition coefficient: 4.91
Compound 3: the middle estimate sits 0.41 log units below what was measured, and the stated range covers the measured number.
By their numbers in this assay, from the lowest: compounds 2 and 1 (each within the scatter of the next); then compound 3.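

In this assay, the hydrogen on an oxygen next to a carbonyl group proves to be a place where one change can move the number a long way: sec-butyl in place of that hydrogen, which turns carboxy into sec-butoxycarbonyl, gives a number 2.19 log units higher from compound 2 to compound 3 (beyond the scatter) in a single step. Among the compounds shown here, the earlier compounds could not show this, since their only step, a number 0.08 log units lower from compound 1 to compound 2 (within the scatter), lies elsewhere, on a saturated chain carbon, and gave no sign that any one place on the shared core could matter this much. Nothing measured here speaks to why the new step is this large.

A single replacement at this oxygen cannot tell whether a step of this size belongs to sec-butyl in particular or would come with other groups there. Ethyl or a longer straight chain on the same oxygen, or a primary amide in place of the carboxy group, would show how the number follows the size and kind of what enters.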